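A few compounds are considered here, and "the series" means these few. Any claim that something is new, unique, unknown or untested is made for them only; others in the source may bear on it.

Compound 2 `O=C(O)COc1ccc(NC(=O)C(=O)Nc2ccccc2Cl)cc1F` gives 10.2% in a functional assay on CHO cells for agonist activity at Free fatty acid receptor 1 (Homo sapiens), read by FLIPR, tested at 100 nM (on this read-out lower numbers stand for a weaker effect and higher numbers for a stronger effect at the one concentration tested), the lowest of the two numbers recorded so far; its nearest neighbour is compound 1 `Cc1cccc(NC(=O)C(=O)Nc2ccc(OCC(=O)O)c(F)c2)c1`, which gives 17.7%, a value within the scatter of compound 2. For the measured compounds named here, the single measured step, a number 7.5 percentage points lower from compound 1 to compound 2 (within the scatter), exchanges 3-methylphenyl for 2-chlorophenyl and stayed within the scatter; it is a different kind of change from the one that follows, so no measured step bears directly on it. Compound 3 `O=C(O)COc1ccc(NC(=O)C(=O)Nc2cccc(Cl)c2)cc1F` differs from compound 2 by 3-chlorophenyl in place of 2-chlorophenyl on an amide-type nitrogen. Going by the values given here, with no comparable step on record, nothing beyond the scatter is expected, and the step of a number 1.8 percentage points higher from compound 2 to compound 3 (within the scatter) is estimated to be flat. Compound 3 is therefore expected to give about 12% in this assay , with a range from 2% to 28%.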

Compound 3, a percentage reported as activity, at one concentration (the size of the read-out at that concentration, not a potency): 13.3%
Compound 3: the middle estimate sits 1.3 percentage points below what was measured, and the stated range covers the measured number.
By their numbers in this assay, from the lowest: compounds 2, 3 and 1 (each within the scatter of the next).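

In this assay the exchange of 2-chlorophenyl for 3-chlorophenyl on the amide-type nitrogen gives a number 3.1 percentage points higher from compound 2 to compound 3 (within the scatter) and so gives the first read on where the chloro sits on this ring: the two placements cannot be told apart here. The exchange of methyl for chloro on an aromatic carbon gives a number 4.4 percentage points lower from compound 1 to compound 3 (within the scatter) and likewise does not separate the two substituents, so all three compounds stay within the scatter of one another on this read-out. No measured evidence bears on why these changes leave the read-out flat.

On these data alone, whether a trifluoromethyl, methoxy or nitrile group at this aromatic carbon would move the number beyond the scatter remains open. As far as these compounds go, since each value comes from one concentration, it also remains open whether these compounds would differ in the strength of their effect at any other concentration.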